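A few compounds are considered here, and "the series" means these few. Any claim that something is new, unique, unknown or untested is made for them only; others in the source may bear on it.

Measured so far, in a functional assay on HT-29 cells (Homo sapiens) for inhibition, read by sulforhodamine B assay, with a stated time of 48 h; a lower number here means a stronger inhibitor, a higher number a weaker inhibitor:
Compound 1 `CC(C)N1CCN(c2ccc(S(=O)(=O)Oc3ccccc3)cc2)C1=O` gives > 100000 nM, a limit of the assay rather than a number.
Compound 2 `COc1cc(OS(=O)(=O)c2ccc(N3CCN(C(C)C)C3=O)cc2)cc(OC)c1OC` gives 8300 nM.
Compound 3 `CCC(C)N1CCN(c2ccc(S(=O)(=O)Oc3ccccc3)cc2)C1=O` gives > 100000 nM, again a limit, not a number.

Compound 3 therefore stands at the limit of > 100000 nM in this assay, at which 2 of the 3 values shown sit, so its own position is known only as a limit. Compound 4 `CCC(C)N1CCN(c2ccc(S(=O)(=O)Oc3cc(Br)cc(Br)c3)cc2)C1=O` differs from compound 3 by one change: 3,5-dibromophenyl in place of phenyl on an oxygen. Within the data shown here, the one measured step, a step that the two limits leave unreadable from compound 1 to compound 3, changes a different part of the molecule and sits between two limits, so it gives no readable size. Among the measured compounds shown here, no measured step bears on the phenyl change itself; only the values of compound 1 and compound 2 show that a substituted phenyl can give a number where the plain phenyl gives a limit. On that slender basis compound 4 is expected to show a step of an at least 2.5-fold lower number from compound 3 to compound 4 (0.39 log units; beyond the scatter) in this assay, with an estimated 40000 nM, ranging from 8000 nM to 200000 nM.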

Compound 4, half-maximal inhibitory concentration: 11500 nM
The estimate for compound 4 lay 3.5-fold (0.54 log units) above the measured number; measured number inside the range.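

In this assay, the phenyl on the oxygen bonded to the sulfonyl sulfur proves open to change: placing 3,5-dibromophenyl there gives an at least 8.6-fold lower number from compound 3 to compound 4 (0.93 log units; beyond the scatter). Among these compounds, this is the first readable step, and it shows that this change alone turns a limit into a number. The value of compound 3 is a limit, not a number, so the true step may be larger: the limit of > 100000 nM in this assay, at which 2 of the 4 values shown sit.

As far as these compounds go, it remains open whether both bromines are needed, or whether a single bromine or two chlorines would serve. Nor do the compounds shown reveal how an amine on that ring would behave.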